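Replacing the pyridin-4-yl on the piperazine-like ring with cycloheptyl

The source may report more compounds than this note shows. Statements on the series, on what has been measured and on what is new or still open speak of the compounds shown alone.

The three compounds measured so far share one core and differ only in the group on an amine nitrogen in a ring; all were tested in a functional assay on CHO cells with adenosine receptor A1 (Homo sapiens) as the target, read by cAMP accumulation and immunoassay, with a stated time of 6 min, tested at 0.1 uM; a higher number here means a weaker effect of the compound at the concentration tested, a lower number a stronger effect:

compound 1 `Nc1scc(CN2CCN(c3cccc(Cl)c3Cl)CC2)c1C(=O)c1ccc(Cl)cc1`, compound 1 gives 3.2%
compound 2 `Nc1scc(CN2CCN(c3ccc(OC(F)(F)F)cc3)CC2)c1C(=O)c1ccc(Cl)cc1`, compound 2 gives -13%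
compound 3 `Nc1scc(CN2CCN(c3ccncc3)CC2)c1C(=O)c1ccc(Cl)cc1`, compound 3 gives 1.4%

Compound 3 has the second highest of the three numbers. Its nearest neighbour is compound 1, with a number 1.8 percentage points lower from compound 1 to compound 3 (within the scatter), a difference within the scatter; its furthest is compound 2, with a number 14.4 percentage points higher from compound 2 to compound 3 (beyond the scatter), a modest gap beyond the scatter. Going by the values given here, the one step that lies beyond the scatter among the measured pairs is a number 16.2 percentage points lower from compound 1 to compound 2 (beyond the scatter).

Compound 4 `Nc1scc(CN2CCN(C3CCCCCC3)CC2)c1C(=O)c1ccc(Cl)cc1` differs from compound 3 in a single place: cycloheptyl in place of pyridin-4-yl on an amine nitrogen in a ring. Among the compounds with values here, every measured step concerns the same position, so all three bear on it, but none brings in a seven-membered non-aromatic ring of carbon only, so there is no direct precedent. The measured steps at this position span only a modest range, and compound 3 is estimated to stay close, with the expected step of a number 1.4 percentage points lower from compound 3 to compound 4 (within the scatter) remaining within the scatter. Compound 4 is therefore estimated at 0%, with a range from -18% to 16%.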

Compound 4, a percentage reported as activity, at one concentration (the size of the read-out at that concentration, not a potency): 13%
Compound 4: the middle estimate sits 13 percentage points below what was measured; the measured number falls inside the stated range.
By their numbers in this assay, from the lowest: compound 2; then compounds 3, 1 and 4 (each within the scatter of the next, the first and the last beyond it).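

In this assay, going by these compounds alone, compound 4 is the first in this set to carry a non-aromatic ring of carbon only on the amine nitrogen, and the change gives a number 11.6 percentage points higher from compound 3 to compound 4 (beyond the scatter) but a number 9.8 percentage points higher from compound 1 to compound 4 (within the scatter), so an aromatic ring at this position is not needed for a number level with that of compound 1. Within the data shown here, compounds 1 and 3 lie within the scatter of each other, yet only the step from compound 3 passes beyond it, which shows that the reading of this change depends on the comparison chosen, while a number 26 percentage points higher from compound 2 to compound 4 (beyond the scatter) is the widest step seen at this position and sets cycloheptyl clearly apart only from 4-(trifluoromethoxy)phenyl. No evidence is available that would account for these differences.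

From the compounds shown here alone, what remains open is whether the size of the ring or the loss of the aromatic ring matters more, a question that cyclohexyl or unsubstituted phenyl on the same nitrogen could help to separate. An open chain such as n-heptyl would likewise test whether a ring is needed here at all.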